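Swapping a Side Chain on a Sulfonyl Sulfur

A few compounds are considered here, and "the series" means these few. Any claim that something is new, unique, unknown or untested is made for them only; others in the source may bear on it.

Among the measured compounds shown here, in an ADME assay on microsomes from liver (Homo sapiens) for metabolic stability, read by LC-MS, using NADPH, with a stated time of 30 min, tested at 0.1 uM (a lower number here means that less of the compound is left, a higher number that more of the compound is left), compound 1 (`O=S(=O)(NCC1COC1)c1cccc(-c2ccc3nccc(-c4ccncc4)c3n2)c1`) gives 2% and stands lowest of the three compounds measured so far. In this assay compound 3 (`O=S(=O)(NCCN1CCCC1)c1cccc(-c2ccc3nccc(-c4ccnc(C(F)(F)F)c4)c3n2)c1`) gives 14% which is a small gap from compound 1 but still beyond the scatter. Compound 2 (`CS(=O)(=O)Nc1ccc2nccc(-c3ccncc3)c2n1`) gives 96% at the far top of the range. For the measured compounds named here, neither of these two compounds differs from compound 1 in just one place, so no measured step serves as a direct guide.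

Compound 4 (`O=S(=O)(CCO)c1cccc(-c2ccc3nccc(-c4ccncc4)c3n2)c1`) keeps the core of compound 1 and changes one group. The change is 2-hydroxyethyl in place of ((oxetan-3-yl)methyl)amino on a sulfonyl sulfur and it places 2-hydroxyethyl in place of ((oxetan-3-yl)methyl)amino on a sulfonyl sulfur. Because compound 1 sits at 2% the number has almost no room to fall, so any visible move should be upward. Compound 3 also carries a side chain on a sulfonyl sulfur and gives only 14% so a large rise is not expected. The expected step in this assay is a modest rise a number 13 percentage points higher from compound 1 to compound 4 (beyond the scatter) and it may barely clear the scatter. In this assay the estimated value for compound 4 is 15% with an expected range of 2% to 45% overall.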

Compound 4, percent of the compound remaining: 95%
The estimate for compound 4 lay 80 percentage points below the measured number, outside the stated range (above it).
By their numbers in this assay, from the lowest: compound 1; then compound 3; then compounds 4 and 2 (each within the scatter of the next).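

On the shared core, the group on a sulfonyl sulfur is enough on its own to move the read-out across nearly the whole range seen here: in this assay, placing 2-hydroxyethyl in place of ((oxetan-3-yl)methyl)amino gives a step of a number 93 percentage points higher from compound 1 to compound 4 (beyond the scatter), a large change for a single swap. This shows that the core of compound 1 does not by itself hold the number low, and that the count of hydrogen-bond donors and acceptors does not separate the two groups, since both sides of the change carry the same count. The swap removes the nitrogen, the four-membered ring and some heavy atoms all at once, and nothing shown gives a reason for the rise or says which of these removals matters.

Going by these compounds, a 2-hydroxyethylamino group on the sulfonyl sulfur would keep the nitrogen without the ring, while a plain (oxetan-3-yl)methyl group would keep the ring without the nitrogen, and how either would read remains open. Also open, on these data alone, is whether a longer chain, such as 3-hydroxypropyl, would hold the number as high as compound 4 does.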